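Swapping 4-fluorophenyl for 3-methylphenyl on compound 2

A few compounds are considered here, and "the series" means these few. Any claim that something is new, unique, unknown or untested is made for them only; others in the source may bear on it.

Values in a functional assay on A2780 cells (Homo sapiens) for inhibition, read by MTT assay, with a stated time of 72 h; a lower number here means a stronger inhibitor, a higher number a weaker inhibitor
- compound 1 `Cc1ccc(CN2CCc3ncn(COCc4ccccc4)c3/C(=C/c3ccccc3)C2=O)cc1` gives 21200 nM
- compound 2 `O=C1/C(=C\c2ccccc2)c2c(ncn2COCc2ccccc2)CCN1Cc1ccc(F)cc1` gives 24800 nM
- compound 3 `Cc1cc(C)cc(CN2CCc3ncn(COCc4ccccc4)c3/C(=C/c3ccccc3)C2=O)c1` gives 31300 nM

Compound 2 lies within the scatter of both other compounds, so these three cannot be ranked. Compound 4 `Cc1cccc(CN2CCc3ncn(COCc4ccccc4)c3/C(=C/c3ccccc3)C2=O)c1` carries one change from compound 2 in the form of 3-methylphenyl in place of 4-fluorophenyl on a saturated chain carbon bound to an amide-type nitrogen in a ring with 3-methylphenyl in place of 4-fluorophenyl. Within the data shown here, two measured steps bear on this. One is a 1.2-fold higher number from compound 1 to compound 2 (0.07 log units; within the scatter) for fluoro in place of methyl on an aromatic carbon, and the other, a 1.3-fold higher number from compound 2 to compound 3 (0.10 log units; within the scatter) also replaces 4-fluorophenyl. Both stay within the scatter, so no real shift is expected in this assay here. The expected size is a 1.0-fold higher number from compound 2 to compound 4 (0.02 log units; within the scatter) and no clear direction is anticipated. For compound 4 the estimate is 26000 nM within an expected range from 15000 nM to 42000 nM in this test.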

Compound 4, half-maximal inhibitory concentration: 26300 nM
Estimate against measurement, compound 4: 1.0-fold (0.00 log units) below, within the range that was stated.
By their numbers in this assay, from the lowest: compounds 1, 2, 4 and 3 (each within the scatter of the next).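

In this assay, 3-methylphenyl in place of 4-fluorophenyl gives a 1.1-fold higher number from compound 2 to compound 4 (0.03 log units; within the scatter), 3-methylphenyl in place of 4-methylphenyl gives a 1.2-fold higher number from compound 1 to compound 4 (0.09 log units; within the scatter), and hydrogen in place of one methyl of 3,5-dimethylphenyl gives a 1.2-fold lower number from compound 3 to compound 4 (0.08 log units; within the scatter). So at this place on the chain carbon, neither fluoro against methyl, nor the ring position of a methyl, nor a second methyl separates these four compounds. Nothing available explains why these values stay so close. As far as these compounds go, all four carry a substituted phenyl here, so whether an amine or a carboxylic acid on that ring would move the number remains open.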